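The source may report more compounds than this note shows. Statements on the series, on what has been measured and on what is new or still open speak of the compounds shown alone.

Measured so far:
compound 1, `Cc1ccccc1-c1nnc(NNC2CCCC2)s1`: > 100 mg/kg
compound 2, `Cc1ccccc1-c1nnc(N(C)NC(C)C)s1`: 38 mg/kg

In a functional assay on the whole organism with Mus musculus as the target, with a stated time of 1 h (a higher number here means that more compound is needed for the effect, a lower number that less compound is needed), compound 1 gives only > 100 mg/kg, a limit of the assay rather than a number; the reading the limit of > 100 mg/kg in this assay, at which 1 of the 2 values shown sits, is where one of the two values sits. Among the measured compounds shown here, compound 2 gives the only numeric value in this assay, 38 mg/kg. For the measured compounds named here, no two measured compounds differ in a single place, so no measured step exists.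

Compound 3, `Cc1ccccc1-c1nnc(N(C)NC2CCCC2)s1`, differs from compound 2 by cyclopentyl in place of isopropyl on an amine nitrogen, the methyl on the other nitrogen kept. Compound 1 also carries cyclopentyl, but it differs from compound 2 in two places, so its limit says nothing about this change on its own. The step from compound 2 to compound 3 is expected to be modest, toward a higher dose, a 1.6-fold higher number from compound 2 to compound 3 (0.20 log units; within the scatter). Compound 3 is thus estimated at 60 mg/kg, within 25 mg/kg to 150 mg/kg, with a fair chance that only a limit is returned.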

Compound 3, dose for half-maximal effect: 81 mg/kg
For compound 3 the middle estimate is 1.4-fold (0.13 log units) below the measured one, within the range that was stated.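

In this assay, cyclopentyl in place of isopropyl on an amine nitrogen gives a 2.1-fold higher number from compound 2 to compound 3 (0.33 log units; beyond the scatter), so this position accepts the ring but needs more compound with it than with isopropyl. Methyl in place of hydrogen on a nitrogen on an aromatic ring, with cyclopentyl kept, gives an at least 1.2-fold lower number from compound 1 to compound 3 (0.09 log units; that floor lies within the scatter), which does not establish a real gain from the methyl. Compound 1 stands at a limit and not a number, and the true size of this step stays unknown: the limit of > 100 mg/kg in this assay, at which 1 of the 3 values shown sits.

On these data alone, with only isopropyl and cyclopentyl compared directly on this amine nitrogen, it remains open how ethyl, tert-butyl or cyclohexyl would read there. Also open, as far as these compounds go, is whether a longer chain ending in a hydroxyl or an amine would be accepted at this position.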